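A few compounds are considered here, and "the series" means these few. Any claim that something is new, unique, unknown or untested is made for them only; others in the source may bear on it.

Of the compounds shown here, two built on one shared core have been measured in an ADME assay on the whole organism (Rattus norvegicus), at a dose of 2 mg/kg by the oral route; on this read-out higher numbers stand for higher exposure at the dose given and lower numbers for lower exposure. Compound 1 `COc1cc(OCc2csc(-c3ccc(C(F)(F)F)cc3)n2)c2cc(-c3cn4nc(OC)sc4n3)oc2c1` carries a trifluoromethyl group on its outer benzene ring, and in this assay compound 1 gives 726 ng.h/mL. Compound 2 `COc1cc(OCc2csc(-c3ccc(C(C)(C)O)cc3)n2)c2cc(-c3cn4nc(OC)sc4n3)oc2c1` carries 1-hydroxy-1-methylethyl at that same place instead, and in this assay compound 2 gives 505 ng.h/mL. The step of a 1.4-fold lower number from compound 1 to compound 2 (0.16 log units; within the scatter) is too small to count as a real change. Compound 2 thus stands at the lower of the two numbers, but the gap to compound 1 lies within the scatter, so no true difference between them is shown.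

Compound 3 `CNC(=O)c1ccc(-c2nc(COc3cc(OC)cc4oc(-c5cn6nc(OC)sc6n5)cc34)cs2)cc1` has not yet been measured. Its difference from compound 2 is methylcarbamoyl in place of 1-hydroxy-1-methylethyl on an aromatic carbon. This alters the same group, at the same place on the same ring, that was altered between compound 1 and compound 2, and that earlier step stayed within the scatter. Among the measured compounds shown here, with only this one comparison to go on, a step of a 1.1-fold lower number from compound 2 to compound 3 (0.05 log units; within the scatter) is expected, that is, none beyond the scatter. Compound 3 is therefore estimated at 450 ng.h/mL, with a range from 150 ng.h/mL to 1400 ng.h/mL reflecting how widely exposure measurements of this kind spread.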

Compound 3, area under the concentration-time curve: 21.9 ng.h/mL
Beside the measured number, compound 3's estimate is 21-fold (1.31 log units) above it; the measured number lies below the stated range.
By their numbers in this assay, from the lowest: compound 3; then compounds 2 and 1 (each within the scatter of the next).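

In this assay, the group at this position clearly matters: the earlier swap between trifluoromethyl and 1-hydroxy-1-methylethyl stayed within the scatter, yet methylcarbamoyl brings a 23-fold lower number from compound 2 to compound 3 (1.36 log units; beyond the scatter) and, set against trifluoromethyl, a 33-fold lower number from compound 1 to compound 3 (1.52 log units; beyond the scatter) on the same read-out. The change from 1-hydroxy-1-methylethyl to methylcarbamoyl leaves the number of heavy atoms, hydrogen-bond donors and hydrogen-bond acceptors as it was, and neither group carries a net charge, so these counts do not separate a group that keeps exposure from one that loses most of it. No measurement at hand says why exposure falls so far with this group.

The compounds shown leave open whether the fall belongs to methylcarbamoyl as a whole or to one part of it, and a dimethylcarbamoyl group, which has no amide hydrogen, or a plain carbamoyl group would speak to that. Also open, from the compounds shown here alone, is whether the same change would act alike on another core, and whether the low exposure reflects how much compound enters the blood or how fast it leaves, since a single oral exposure figure cannot separate the two.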